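This account rests on a few compounds, and the source may have more. Where it says the series, first, only, none or still open, it means among the compounds named here.

In a functional assay on the whole organism (strain albino) for inhibition, with Rattus norvegicus as the target, read by paw edema, with stated times of 30 min and 1 h, at a dose of 100 mg/kg by the oral route (on this read-out higher numbers stand for more inhibition at the one dose given (going by the name of the read-out) and lower numbers for less inhibition), compound 1 `COc1ccc(C2=NN(C(=O)CBr)C(c3ccco3)C2)cc1OC` gives 38%. Within the data shown here, compound 2 `COc1ccc(C2=NN(C(=O)CO[N+](=O)[O-])C(c3ccco3)C2)cc1OC` gives 32%, the lowest of the two numbers so far, with compound 1 as its only neighbour, and the step of a number 6 percentage points lower from compound 1 to compound 2 (within the scatter) shows the two compounds cannot be told apart on this read-out. Compound 3 `COc1ccc(C2=NN(C(=O)CNc3ccc(/C(C)=N/O)cc3)C(c3ccco3)C2)cc1OC` differs from compound 2 at the same place: a group of 11 heavy atoms (8 carbon, 2 nitrogen, 1 oxygen; one six-membered aromatic ring of carbon only) in place of a group of 4 heavy atoms (1 nitrogen, 3 oxygen; no ring), on a saturated chain carbon bound to a carbonyl carbon. Among the measured compounds shown here, the one measured step bears on it only loosely: it exchanged one small group for another on a saturated chain carbon bound to a carbonyl carbon. For the measured compounds named here, no measured step shows a group of 11 heavy atoms with one six-membered aromatic ring of carbon only entering at that carbon, so the direction of the change cannot be read from the data. The step of a number 6 percentage points higher from compound 2 to compound 3 (within the scatter) is therefore expected to be small, with a wide range around it. For compound 3 the estimate in this assay is 38%, between 15% and 62%.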

Compound 3, a percentage reported as inhibition, in the whole organism at one dose (the size of the read-out at that dose, not a potency): 38%
For compound 3 middle estimate and measured number coincide at the digits printed; the measured number falls inside the stated range.
By their numbers in this assay, from the lowest: compounds 2, 1 and 3 (each within the scatter of the next).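

In this assay, the saturated chain carbon bound to a carbonyl carbon accepts a group of 11 heavy atoms with one six-membered aromatic ring of carbon only, and the read-out stays within the scatter: the record shows a number 6 percentage points higher from compound 2 to compound 3 (within the scatter) and no change at the digits printed from compound 1 to compound 3 (within the scatter) for this group. Bromo, nitrooxy and the new ring-bearing group therefore cannot be told apart at this one dose, so among these three compounds the size of the group and its ring show no readable link to the number. Nothing available here accounts for this result.

Open, from the compounds shown here alone, is whether an amine, a carboxylic acid or a longer chain at that carbon would read differently from these three groups. Also open, going by these compounds, is whether the aromatic ring of compound 3 would give a similar number without its oxime.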